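The source may hold more compounds than are shown below. What is called first, only, known or untested is meant among the compounds shown, and "the series" means these compounds.

Compound 1 `C=CCn1c(=O)/c(=C\c2ccccc2C(F)(F)F)[nH]c(=O)/c1=C\c1ccccc1OC` and compound 2 `C=CCn1c(=O)/c(=C\c2ccc(F)c(Br)c2)[nH]c(=O)/c1=C\c1ccccc1OC` share one core and differ only in the aryl group on a double-bonded chain carbon bound to an aromatic carbon. In a functional assay on NCI-H1975 cells (Homo sapiens) for cytotoxicity, read by CCK-8 assay, with a stated time of 72 h (on this read-out lower numbers stand for stronger inhibition and higher numbers for weaker inhibition), compound 1 gives 14500 nM, while compound 2 is reported as "not active" (no number reported) with no single number, so compound 2 cannot be placed on a scale against compound 1; it stands only as the weaker reading of the pair. Compound 3 `C=CCn1c(=O)/c(=C\c2cc(F)ccc2C)[nH]c(=O)/c1=C\c1ccccc1OC` is the next variation: 5-fluoro-2-methylphenyl in place of 3-bromo-4-fluorophenyl on a double-bonded chain carbon bound to an aromatic carbon. Among the compounds with values here, no measured step covers this exchange, so the expected size and direction of the change cannot be taken from the set. For compound 3 in this assay the estimate is 25000 nM, within 6000 nM to 100000 nM.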

Compound 3, half-maximal inhibitory concentration: 7300 nM
The estimate for compound 3 lay 3.4-fold (0.53 log units) above the measured number; the range from low to high includes it.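

In this assay, compound 3 gives a number where compound 2 gives none, so the step between these two cannot be read. Against 2-(trifluoromethyl)phenyl, the exchange to 5-fluoro-2-methylphenyl gives a 2.0-fold lower number from compound 1 to compound 3 (0.30 log units; within the scatter) and does not separate these two aryl groups. No measured evidence bears on why the readings fall as they do.

Open, on these data alone, is how an aryl group carrying an amine or a carboxylic acid would read at this place. Also open, as far as these compounds go, is whether the fluorine or the methyl of 5-fluoro-2-methylphenyl matters when taken singly.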